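This account rests on a few compounds, and the source may have more. Where it says the series, first, only, none or still open, it means among the compounds named here.

Measured in an ADME assay on MT4 cells (Homo sapiens) for cytotoxicity, read by MTT assay; on this read-out higher numbers stand for lower toxicity in this test and lower numbers for higher toxicity in this test:
Compound 1 `COc1ccc(C(=O)CSc2nc(Cc3c(F)cccc3Cl)cc(=O)[nH]2)cc1` gives > 12000 nM as a limit.
Compound 2 `CCc1c(Cc2c(F)cccc2Cl)nc(SCC(=O)c2ccc(OC)cc2)[nH]c1=O` gives > 11000 nM as a limit.
Compound 3 `COc1ccc(C(=O)CSc2nc(Cc3c(F)cccc3Cl)c(C(C)C)c(=O)[nH]2)cc1` gives > 11000 nM as a limit.

Compound 3 stands at the limit of > 11000 nM in this assay, at which 2 of the 3 values shown sit, so no number is known for it. Compound 4 `CCC(C)c1c(Cc2c(F)cccc2Cl)nc(SCC(=O)c2ccc(OC)cc2)[nH]c1=O` differs from it as follows: methyl in place of hydrogen on a saturated chain carbon, two bonds along the chain from an aromatic carbon, a methyl in place of hydrogen on a saturated chain carbon, two bonds along the chain from an aromatic carbon, taking isopropyl to sec-butyl.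

Within the data shown here, the closest precedent is a step that the two limits leave unreadable from compound 2 to compound 3. The other two are a step that the two limits leave unreadable from compound 1 to compound 2 and a step that the two limits leave unreadable from compound 1 to compound 3. None gives a size, and none points in a direction.

In this assay no step beyond the scatter is expected, and the estimated change is an at least 1.0-fold lower number from compound 3 to compound 4 (0.02 log units; that floor lies within the scatter). A further limit is the likely outcome.

Compound 4 is estimated at 10500 nM, with an expected range of 6000 nM to 13000 nM.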

Compound 4, half-maximal cytotoxic concentration: 40000 nM
For compound 4 the middle estimate is 3.8-fold (0.58 log units) below the measured one; the measured number lies above the stated range.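

Against compound 1, compound 2 and compound 3, which carry only limits in this assay, compound 4 yields no readable step. From the compounds shown here alone, whether sec-butyl in compound 4 truly shifts this assay relative to hydrogen, ethyl or isopropyl remains open.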